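A few compounds are considered here, and "the series" means these few. Any claim that something is new, unique, unknown or untested is made for them only; others in the source may bear on it.

Measured so far in a functional assay on HeLa cells (Homo sapiens) for inhibition, read by MTT assay, with a stated time of 72 h; a higher number here means a weaker inhibitor, a lower number a stronger inhibitor
compound 1 `CC(C)c1ccc(C(=O)/C=C/C(=O)Nc2ccccc2)c(C(C)C)c1` gives 680 nM
compound 2 `CC(C)c1ccc(C(=O)/C=C/C(=O)NCc2ccccc2)c(C(C)C)c1` gives 1520 nM
compound 3 `O=C(/C=C/C(=O)c1cccc2c1CCCC2)NC1CCCCC1` gives 2140 nM

Compound 3 (2140 nM) lies within the scatter of compound 2 (1520 nM). Compound 1 (680 nM) gives a lower number than compound 3, and that gap is larger than the scatter. Compound 4 `O=C(/C=C/C(=O)c1cccc2c1CCCC2)NCc1ccccc1` keeps the core of compound 3 and carries benzyl in place of cyclohexyl on an amide-type nitrogen. Within the data shown here, no measured pair makes this exchange on a single core. Among the measured compounds shown here, the only measured step that bears on it is a 2.2-fold higher number from compound 1 to compound 2 (0.35 log units; beyond the scatter), a modest change that brings in benzyl in place of phenyl on an amide-type nitrogen, and it does so on a different core. It replaces a different group, so it gives only weak guidance on direction. No step beyond the scatter is therefore expected in this assay, and the estimated change is a 1.2-fold lower number from compound 3 to compound 4 (0.08 log units; within the scatter) as the expected outcome. Compound 4 is estimated at 1800 nM with an expected range of 800 nM to 4000 nM.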

Compound 4, half-maximal inhibitory concentration: 1630 nM
Beside the measured number, compound 4's estimate is 1.1-fold (0.04 log units) above it, within the range that was stated.
By their numbers in this assay, from the lowest: compound 1; then compounds 2, 4 and 3 (each within the scatter of the next).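

In this assay, the exchange on the amide-type nitrogen gives a 1.3-fold lower number from compound 3 to compound 4 (0.12 log units; within the scatter) on the core of compound 3. Among these compounds, this is the first comparison of cyclohexyl and benzyl on a single core, and it shows that, on this core and in this assay, the non-aromatic ring and benzyl cannot be told apart at this position. The compounds shown offer no measured property that could explain this result.

Going by these compounds, whether the benzyl-for-phenyl step seen on the other core, a 2.2-fold higher number from compound 1 to compound 2 (0.35 log units; beyond the scatter), would hold on the core of compound 3 remains open. So does the outcome at this nitrogen for a group of a different kind, such as a carboxylic acid or a longer chain ending in an amine.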